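From isobutyl to cyclohexyl on the shared core

The source may hold more compounds than are shown below. What is called first, only, known or untested is meant among the compounds shown, and "the series" means these compounds.

Measured so far in an ADME assay on microsomes from liver (Rattus norvegicus) for metabolic stability, with a stated time of 60 min (a higher number here means that more of the compound is left, a lower number that less of the compound is left), are two compounds:
- compound 1 (`O=C(O)c1cc(-c2cccc(COc3ccc4c(c3)CN(Cc3ccc(C(F)(F)F)cc3)C4=O)c2)ccc1Cl`) with 100%
- compound 2 (`CC(C)CN1Cc2cc(OCc3cccc(-c4ccc(Cl)c(C(=O)O)c4)c3)ccc2C1=O`) with 43%

Of these two numbers, compound 2 holds the lower one. Compound 3 (`O=C(O)c1cc(-c2cccc(COc3ccc4c(c3)CN(C3CCCCC3)C4=O)c2)ccc1Cl`) puts cyclohexyl in place of isobutyl on an amide-type nitrogen in a ring. Among the compounds with values here, the one measured step that bears on this change is a number 57 percentage points lower from compound 1 to compound 2 (beyond the scatter) and it came with isopropyl in place of 4-(trifluoromethyl)phenyl on a saturated chain carbon bound to an amide-type nitrogen in a ring. That step removed an aromatic group, whereas compound 3 carries none in this place, just as compound 2 (43%) carries none. Within the data shown here, no step of that size is therefore expected, and none beyond the scatter. The expected step is a number 2 percentage points higher from compound 2 to compound 3 (within the scatter) by this estimate. In this assay compound 3 is expected to give 45% with a range from 20% to 75% around that figure.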

Compound 3, percent of the compound remaining: 1%
Beside the measured number, compound 3's estimate is 44 percentage points above it, outside the stated range (below it).
By their numbers in this assay, from the lowest: compound 3; then compound 2; then compound 1.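

In this assay, cyclohexyl in place of isobutyl on the amide-type nitrogen gives a number 42 percentage points lower from compound 2 to compound 3 (beyond the scatter), so this place remains sensitive even among groups of carbon only with no aromatic ring. Cyclohexyl in place of 4-(trifluoromethyl)benzyl gives a number 99 percentage points lower from compound 1 to compound 3 (beyond the scatter), which shows that the earlier step did not set a floor for this position. Nothing available explains why the two carbon-only groups differ.

The compounds shown cannot separate the effect of the ring from that of its direct attachment to the nitrogen, since cyclohexylmethyl, which would hold the same ring through a chain carbon, is not among them. Going by these compounds, whether a smaller ring such as cyclopropyl, or an unsubstituted benzyl, would stand nearer compound 1 or compound 3 also stays open.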